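This account rests on a few compounds, and the source may have more. Where it says the series, first, only, none or still open, it means among the compounds named here.

Measured so far:
compound 1 `CN(C(=O)NC(=O)c1cccc([N+](=O)[O-])c1)c1nc(C(F)(F)F)c(C(=O)N/N=C/c2ccccc2C(F)(F)F)s1` — 4.8 ug/mL
compound 2 `CNc1nc(C(F)(F)F)c(C(=O)N/N=C/c2ccccc2C(F)(F)F)s1` — > 100 ug/mL
compound 3 `CN(C(=O)NC(=O)c1cccc(C(F)(F)F)c1)c1nc(C(F)(F)F)c(C(=O)N/N=C/c2ccc(C(F)(F)F)cc2)s1` — 7.71 ug/mL

In a functional assay on HepG2 cells (Homo sapiens) for inhibition, read by MTT assay, with a stated time of 72 h (a higher number here means a weaker inhibitor, a lower number a stronger inhibitor), compound 1 gives 4.8 ug/mL, the lowest of the two numbers. Compound 3 gives 7.71 ug/mL, and the gap to compound 1 lies within the scatter, so neither is called the stronger. For compound 2 the result is a limit of the assay, not a number: the limit of > 100 ug/mL in this assay, at which 1 of the 3 values shown sits. Among the measured compounds shown here, no two measured compounds differ in one place only, so no measured step is at hand.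

Compound 4 `CN(C(=O)NC(=O)c1ccc(Cl)cc1Cl)c1nc(C(F)(F)F)c(C(=O)N/N=C/c2ccccc2C(F)(F)F)s1` differs from compound 1 in one place: 2,4-dichlorophenyl in place of 3-nitrophenyl on a carbonyl carbon. With nothing measured on this kind of change, no step beyond the scatter is expected in this assay, in either direction; the expected step is a 1.1-fold higher number from compound 1 to compound 4 (0.06 log units; within the scatter). Compound 4 is therefore estimated at 5.5 ug/mL, with a range from 2 ug/mL to 20 ug/mL.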

Compound 4, half-maximal inhibitory concentration: 10.7 ug/mL
For compound 4 the middle estimate is 1.9-fold (0.29 log units) below the measured one; the range from low to high includes it.
By their numbers in this assay, from the lowest: compounds 1, 3 and 4 (each within the scatter of the next, the first and the last beyond it). At a limit, above all of these: compound 2.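

Swapping 3-nitrophenyl for 2,4-dichlorophenyl on the carbonyl carbon gives the first readable step in this series, a 2.2-fold higher number from compound 1 to compound 4 (0.35 log units; beyond the scatter) in this assay, so this position responds modestly to the aryl group. Even without the nitro group, compound 4 keeps a measured value of 10.7 ug/mL rather than a limit. Nothing shown here accounts for this step.

From the compounds shown here alone, the separate roles of the two chlorines remain open, since a single change cannot divide the step between them. Also open, going by these compounds, is how 3-aminophenyl or a non-aromatic group such as cyclohexyl would read at this place.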